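The source may report more compounds than this note shows. Statements on the series, on what has been measured and on what is new or still open speak of the compounds shown alone.

Of the compounds shown here, three have been measured in an assay on membranes from brain for binding affinity to Lysophosphatidylserine lipase ABHD12 (Mus musculus), read by fluorescence, with a stated time of 20 min (a higher number here means a weaker inhibitor, a lower number a stronger inhibitor), all sharing one core that differs only in the substitution of its pyridine ring. Compound 1 `FC(F)(F)c1ccnc(N2CCC(NC(=S)Nc3cccnc3)CC2)c1` gives 640 nM in this assay. Compound 3 `FC(F)(F)c1ccnc(N2CCC(NC(=S)Nc3cccnc3)CC2)c1Cl` carries an added chloro on an aromatic carbon and gives 300 nM, a step of a 2.1-fold lower number from compound 1 to compound 3 (0.33 log units; beyond the scatter). Compound 2 `Cc1cnc(N2CCC(NC(=S)Nc3cccnc3)CC2)c(Cl)c1` gives 3100 nM; it differs from compound 1 in more than one place, so its value and that of compound 1 can only be set side by side. Among these three numbers compound 1 stands second highest: nearest to compound 3 and furthest from compound 2.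

Compound 4 `S=C(Nc1cccnc1)NC1CCN(c2cc(OCC3CC3)ccn2)CC1` has not been measured. It differs from compound 1 by cyclopropylmethoxy in place of trifluoromethyl on an aromatic carbon, the new group sitting opposite the ring nitrogen. Among the measured compounds shown here, no measured step in this set touches that position or exchanges the trifluoromethyl for anything else; the only step known, from compound 1 to compound 3, concerns a different carbon and a different group. There is therefore no basis in the data for expecting a step in either direction beyond the scatter, and the expectation for compound 4 must be wide. Compound 4 is estimated at 900 nM in this assay, with a range from 250 nM to 3500 nM, which means an expected step of a 1.4-fold higher number from compound 1 to compound 4 (0.15 log units; within the scatter).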

Compound 4, half-maximal inhibitory concentration: 4700 nM
Compound 4: the middle estimate sits 5.2-fold (0.72 log units) below what was measured, and the stated range ends below it.
By their numbers in this assay, from the lowest: compound 3; then compound 1; then compounds 2 and 4 (each within the scatter of the next).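

In this assay, among the compounds shown here, the exchange of trifluoromethyl for cyclopropylmethoxy on the aromatic carbon opposite the ring nitrogen gives a 7.3-fold higher number from compound 1 to compound 4 (0.87 log units; beyond the scatter) and is the first sign that the group on this carbon matters to the number read. For the compounds shown here, the only earlier step, a 2.1-fold lower number from compound 1 to compound 3 (0.33 log units; beyond the scatter), came from a chloro on a different carbon and ran the other way, so the two changes made to compound 1 move the number in opposite directions. Nothing available accounts for the rise seen with cyclopropylmethoxy.

With a single replacement on this carbon, the compounds shown do not separate the loss of trifluoromethyl from the arrival of the ether oxygen or of the three-membered ring; a methoxy, a plain cyclopropyl or a nitrile in the same place would bear on that. They also leave open whether the chloro step seen in compound 3 would carry over to the cyclopropylmethoxy compound, and whether an amine or a longer ether chain on this carbon would behave like either group.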